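The source may hold more compounds than are shown below. What is called first, only, known or untested is meant among the compounds shown, and "the series" means these compounds.

Measured compounds:
Compound 1 `CC(C)(C)c1cn(C[C@H](O)[C@H]2OC(=O)C(OCc3ccccc3)=C2OCc2ccccc2)nn1`: 54900 nM
Compound 2 `O=C1O[C@H]([C@@H](O)Cn2cc(CNS(=O)(=O)c3ccc(Cl)cc3)nn2)C(OCc2ccccc2)=C1OCc1ccccc1`: 38900 nM

In a functional assay on CFPAC-1 cells (Homo sapiens) for antiproliferative activity, read by MTT assay, with a stated time of 72 h (on this read-out lower numbers stand for stronger inhibition and higher numbers for weaker inhibition), compound 2 gives 38900 nM, and compound 1 gives 54900 nM. The step of a 1.4-fold lower number from compound 1 to compound 2 (0.15 log units; within the scatter) lies within the scatter, so compound 2 stands level with compound 1 rather than apart from it; both numbers are weak on this read-out.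

Compound 3 `Cc1ccc(S(=O)(=O)NCc2cn(C[C@H](O)[C@H]3OC(=O)C(OCc4ccccc4)=C3OCc3ccccc3)nn2)cc1` differs from compound 2 by methyl in place of chloro on an aromatic carbon. Among the compounds with values here, the only step measured so far, a 1.4-fold lower number from compound 1 to compound 2 (0.15 log units; within the scatter), exchanged the whole tert-butyl for the ((4-chlorophenyl)sulfonyl)amino)methyl arm and still produced no change beyond the scatter. No measured pair exchanges chloro for methyl, so nothing in these data speaks for a shift in either direction from such a small substitution at the (4-chlorophenyl)sulfonyl end. The step from compound 2 to compound 3 in this assay is therefore expected to be a 1.0-fold higher number from compound 2 to compound 3 (0.01 log units; within the scatter), that is, none beyond the scatter. Compound 3 is estimated at 40000 nM, with a range from 15000 nM to 110000 nM.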

Compound 3, half-maximal inhibitory concentration: 68000 nM
Compound 3: middle estimate off by 1.7-fold (0.23 log units), on the low side, within the range that was stated.
By their numbers in this assay, from the lowest: compounds 2, 1 and 3 (each within the scatter of the next).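

In this assay, the exchange on an aromatic carbon para to a large group now has a measured size: a 1.7-fold higher number from compound 2 to compound 3 (0.24 log units; within the scatter). On these numbers, 4-methylphenyl and 4-chlorophenyl cannot be told apart at this position, so this single-atom exchange joins the larger exchange of the whole arm in producing no change that can be read. The methyl-bearing arm also stands level with the tert-butyl group, with a 1.2-fold higher number from compound 1 to compound 3 (0.09 log units; within the scatter), which leaves compounds 1, 2 and 3 within the scatter of one another and gives no evidence on why the numbers sit where they do.

With only chloro and methyl shown on this aromatic carbon, it remains open whether a different group there, such as an amine, a carboxylic acid or a longer chain, would move the number beyond the scatter. From the compounds shown here alone, it also remains open whether any change at this end of the molecule can do so while the rest of the shared core stays as it is, since all three compounds give weak numbers on this read-out.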